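A Methoxy Group Added to an Inactive Compound

A few compounds are considered here, and "the series" means these few. Any claim that something is new, unique, unknown or untested is made for them only; others in the source may bear on it.

In a functional assay on KB cells (Homo sapiens) for cytotoxicity, read by MTT assay (a lower number here means a stronger inhibitor, a higher number a weaker inhibitor), compound 1 (`COc1c(O)ccc(C=O)c1OC`) gives > 100000 nM, which is a limit of the assay. Compound 2 (`COc1c(O)ccc(/C=C\Cc2ccc(O)cc2)c1OC`) gives > 100000 nM, also a limit. Compound 2 therefore stands at the limit of > 100000 nM in this assay, at which 2 of the 2 values shown sit. Compound 3 (`COc1cc(C/C=C\c2ccc(O)c(OC)c2OC)ccc1O`) carries a methoxy in place of hydrogen on an aromatic carbon, ortho to a hydroxy group: methoxy in place of hydrogen on an aromatic carbon. Among the compounds with values here, no measured pair shows what this change does, so no change beyond the scatter is expected in this assay. The expected a number no higher from compound 2 to compound 3 (the limit leaves the size open) is small. For compound 3 the estimated value is 100000 nM, within an expected range of 40000 nM to 200000 nM.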

Compound 3, half-maximal inhibitory concentration: 55600 nM
Compound 3: the middle estimate sits 1.8-fold (0.25 log units) above what was measured; the range from low to high includes it.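

In this assay, within the data shown here, methoxy in place of hydrogen on an aromatic carbon, ortho to a hydroxy group, gives the first reading that is a number and not a limit, with an at least 1.7-fold lower number from compound 2 to compound 3 (0.25 log units; that floor lies within the scatter). From the compounds shown here alone, the true size of this step stays unknown, and its floor alone does not show a real change. Compound 3 alone leaves the limit: the limit of > 100000 nM in this assay, at which 2 of the 3 values shown sit.

Still open, going by these compounds, is how an amine or a carboxylic acid in the same place would read. A single methoxy also cannot show whether the same change would matter elsewhere on the core.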